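Cyano in place of nitro on an aromatic carbon

The source may hold more compounds than are shown below. What is called first, only, known or untested is meant among the compounds shown, and "the series" means these compounds.

Among the compounds with values here, in a functional assay on A-375 cells (Homo sapiens) for antiproliferative activity, read by MTT assay, with a stated time of 24 h (on this read-out lower numbers stand for stronger inhibition and higher numbers for weaker inhibition), compound 1 `C=CCOc1ccc2c(=O)c(-c3cc(OC)c(OC)cc3OC)coc2c1` gives 4750 nM, the only true number in this small set. Compound 2 `COc1cc(OC)c(-c2coc3cc(OCC(=O)c4cccc(C(F)(F)F)c4)ccc3c2=O)cc1OC` gives > 10000 nM, which is a limit of the assay and not a number. Compound 3 `COc1cc(OC)c(-c2coc3cc(OCc4ccc([N+](=O)[O-])cc4)ccc3c2=O)cc1OC` gives > 10000 nM, which is also a limit. Compound 3 therefore has no number of its own and stands at the limit of > 10000 nM in this assay, at which 2 of the 3 values shown sit.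

Compound 4 `COc1cc(OC)c(-c2coc3cc(OCc4ccc(C#N)cc4)ccc3c2=O)cc1OC` differs from it in one place: cyano in place of nitro on an aromatic carbon. The cyano group sits on the same aromatic carbon, para to a large group.

Two measured steps lead away from compound 1, with vinyl replaced on the saturated chain carbon: an at least 2.1-fold higher number from compound 1 to compound 3 (0.32 log units; beyond the scatter) and an at least 2.1-fold higher number from compound 1 to compound 2 (0.32 log units; beyond the scatter). Both lie beyond the scatter, but both are bounded by a limit, so neither gives a true size. Between the two limits there is a step that the two limits leave unreadable from compound 2 to compound 3. None of these steps changes the nitro group itself. With compound 3 at > 10000 nM, no step beyond the scatter is expected in this assay, and a further limit is quite possible.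

The estimated change is a number no higher from compound 3 to compound 4 (the limit leaves the size open).

Compound 4 is expected at 10000 nM, with an estimated range of 3500 nM to 30000 nM.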

Compound 4, half-maximal inhibitory concentration: 1550 nM
Compound 4: middle estimate off by 6.5-fold (0.81 log units), on the high side, outside the stated range (below it).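

In this assay the exchange of nitro for cyano on this aromatic carbon, para to a large group, gives an at least 6.4-fold lower number from compound 3 to compound 4 (0.80 log units; beyond the scatter) and so shows that this single group decides whether the (4-nitrobenzyl)oxy type of side chain reads as a number at all. With 4-cyanophenyl on the saturated chain carbon the series also moves past the vinyl compound, with a 3.1-fold lower number from compound 1 to compound 4 (0.49 log units; beyond the scatter) on that side, and past the carbonyl-linked compound, with an at least 6.4-fold lower number from compound 2 to compound 4 (0.80 log units; beyond the scatter) on the other, so among the four compounds shown an aromatic group on this chain carbon is not in itself what costs activity. The steps from compound 2 and compound 3 give only a bound on their size, and the step between those two cannot be read, because both are limits of the assay and not numbers: the limit of > 10000 nM in this assay, at which 2 of the 4 values shown sit.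

The compounds shown leave open whether this gain belongs to cyano alone or would also appear with a chlorine, an amide or a carboxylic acid on the same aromatic carbon. They also leave open whether a cyano group would bring a similar step on the phenyl ring of the carbonyl-linked side chain of compound 2.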